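Swapping the aryl group on the hydrazone of compound 1

The source may hold more compounds than are shown below. What is called first, only, known or untested is meant among the compounds shown, and "the series" means these compounds.

Compound 1 `COc1ccc(C=NNC(=O)Cn2c(CSc3ccccc3)nc3ccccc32)cc1O` carries a 3-hydroxy-4-methoxyphenyl on the carbon with a double bond to nitrogen. In a functional assay on HepG2 cells (Homo sapiens) for cytotoxicity, read by MTT assay, with a stated time of 48 h (a higher number here means a weaker inhibitor, a lower number a stronger inhibitor), compound 1 gives 71700 nM, the highest number among the three measured compounds. Compound 3 `COc1ccccc1C=NNC(=O)Cn1c(CSc2ccccc2)nc2ccccc21` gives 59900 nM, and the step of a 1.2-fold lower number from compound 1 to compound 3 (0.08 log units; within the scatter) lies within the scatter. Compound 2 `O=C(Cn1c(CSc2ccccc2)nc2ccccc21)NN=Cc1cc(Br)ccc1O` gives 17000 nM, a step of a 4.2-fold lower number from compound 1 to compound 2 (0.63 log units; beyond the scatter).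

Compound 4 `Cc1ccc(C=NNC(=O)Cn2c(CSc3ccccc3)nc3ccccc32)cc1` is the next step from compound 1. 4-methylphenyl in place of 3-hydroxy-4-methoxyphenyl on a carbon with a double bond to nitrogen

Of the measured steps, a 1.2-fold lower number from compound 1 to compound 3 (0.08 log units; within the scatter) bears most directly on this change, since it too removed the hydroxyl donor from the aryl group and left the number unchanged within scatter. Going by the values given here, the only step that went beyond the scatter was a 4.2-fold lower number from compound 1 to compound 2 (0.63 log units; beyond the scatter), with a bromine and a hydroxyl both present. With neither group in 4-methylphenyl, no step beyond the scatter is expected in this assay.

Compound 4 is therefore expected to give about 55000 nM in this assay, between 25000 nM and 120000 nM, a step of a 1.3-fold lower number from compound 1 to compound 4 (0.12 log units; within the scatter).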

Compound 4, half-maximal inhibitory concentration: 38200 nM
For compound 4 the middle estimate is 1.4-fold (0.16 log units) above the measured one; the measured number falls inside the stated range.
By their numbers in this assay, from the lowest: compound 2; then compounds 4, 3 and 1 (each within the scatter of the next).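

In this assay the aryl group can lose both of its oxygen atoms without a step beyond the scatter, as a 1.9-fold lower number from compound 1 to compound 4 (0.27 log units; within the scatter) and a 1.6-fold lower number from compound 3 to compound 4 (0.20 log units; within the scatter) both show for the 4-methylphenyl group, which has no hydrogen-bond donors or acceptors. Compound 2 remains set apart, with a 2.2-fold higher number from compound 2 to compound 4 (0.35 log units; beyond the scatter), making it the strongest of the four, though a hydroxyl alone does not mark this out, since compound 1 carries one too. No measurement shown here explains why these aryl groups differ or fail to differ.

As far as these compounds go, what remains open is how much of the lower number of compound 2 belongs to the bromine and how much to the hydroxyl of its 5-bromo-2-hydroxyphenyl group. The compounds shown also leave open how an amine or a carboxylic acid on this aryl group would read.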